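Swapping the hydroxypiperidinyl arm for a tolyl ring

The source may report more compounds than this note shows. Statements on the series, on what has been measured and on what is new or still open speak of the compounds shown alone.

Three compounds of this series carry numbers in a functional assay on DLD-1 cells (Homo sapiens) for antiproliferative activity, read by CellTiter-Glo, with a stated time of 72 h; a higher number here means a weaker inhibitor, a lower number a stronger inhibitor. Compound 1 `Cc1cc(C)c(S(=O)(=O)N2CCC(N3CCC(O)CC3)CC2)c(C)c1` gives 106 nM and stands second highest of the three. Compound 2 `COc1ccc(-c2cccc(S(=O)(=O)N3CCC(N4CCC(C)CC4)CC3)c2)cc1` gives 23 nM, a lower number than compound 1 by a margin beyond the scatter. Compound 3 `CC1CCN(C2CCN(S(=O)(=O)c3ccc(C#N)cc3)CC2)CC1` gives 2800 nM, a higher number than compound 1 by a margin well beyond the scatter. No pair among these three differs in a single place, so no measured step is available to anchor the change considered here.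

Compound 4 `Cc1ccc(C2CCN(S(=O)(=O)c3c(C)cc(C)cc3C)CC2)cc1` differs from compound 1 as follows: 4-methylphenyl in place of 4-hydroxypiperidin-1-yl on a saturated ring carbon. The group that leaves carries the only donor of that arm and its nitrogen; the group that enters carries neither. Nothing measured in this series shows the effect of such a swap.

The step of a 3.8-fold higher number from compound 1 to compound 4 (0.58 log units; beyond the scatter) is expected to run toward a higher number, beyond the scatter but not by a large margin. For compound 4 the estimate is 400 nM, with a range from 60 nM to 3000 nM.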

Compound 4, half-maximal inhibitory concentration: 2200 nM
Estimate against measurement, compound 4: 5.5-fold (0.74 log units) below; measured number inside the range.
By their numbers in this assay, from the lowest: compound 2; then compound 1; then compounds 4 and 3 (each within the scatter of the next).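

In this assay, among the compounds shown here, the change at this saturated ring carbon gives a 21-fold higher number from compound 1 to compound 4 (1.32 log units; beyond the scatter), the first measured single-place step, and it is a large one. The position is therefore sensitive to the identity of its arm, even though the two arms have the same heavy-atom count and each holds a six-membered ring. Nothing measured explains the rise in the number.

The step changes the ring nitrogen, the hydroxyl and the aromatic character of the arm together, so it cannot assign the loss to any one of them. On the core of compound 1, an unsubstituted piperidin-1-yl arm would separate the hydroxyl from the ring nitrogen, and a hydroxycyclohexyl arm would separate the ring nitrogen from the hydroxyl.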